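Replacing a Pyridine Ring with an Isopropoxy Group

The source may hold more compounds than are shown below. What is called first, only, known or untested is meant among the compounds shown, and "the series" means these compounds.

Of the compounds shown here, two sharing one core have been measured. Compound 1 `Cc1ccccc1-c1cc(C(=O)N2CCC3(CC2)CC(=O)c2nn(C(C)(C)C)cc2O3)c2ccccc2n1` carries a 2-methylphenyl group; in a functional assay on MDA-MB-231 cells (Homo sapiens) for inhibition, read by MTT assay, with a stated time of 72 h (on this read-out higher numbers stand for weaker inhibition and lower numbers for stronger inhibition), compound 1 gives only a limit of the assay, > 10000 nM. Compound 2 `CC(C)(C)n1cc2c(n1)C(=O)CC1(CCN(C(=O)c3cc(-c4ccccn4)nc4ccccc34)CC1)O2` bears pyridin-2-yl in its place; in this assay compound 2 gives 8100 nM. Compound 2 thus stands as the only actual number shown; the other value is a limit (the limit of > 10000 nM in this assay, at which 1 of the 2 values shown sits). The step of an at least 1.2-fold lower number from compound 1 to compound 2 (0.09 log units; that floor lies within the scatter) stays within the scatter. Compound 3 `CC(C)Oc1cc(C(=O)N2CCC3(CC2)CC(=O)c2nn(C(C)(C)C)cc2O3)c2ccccc2n1` differs from compound 2 by isopropoxy in place of pyridin-2-yl on an aromatic carbon. Among the measured compounds shown here, no measured step exchanges an aromatic ring for an alkoxy chain, and the one step that exists, from a ring to a ring, did not move the number beyond the scatter, so no step beyond the scatter is expected here either. Compound 3 is therefore estimated at 9000 nM, between 3000 nM and 30000 nM, meaning an expected 1.1-fold higher number from compound 2 to compound 3 (0.05 log units; within the scatter).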

Compound 3, half-maximal inhibitory concentration: > 10000 nM
Compound 3: a limit, no number; the forecaster's own chance of this, stated with the estimate: 40%; middle value at least 1.1-fold (0.04 log units) away from the limit.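

Compound 3 extends the change at this position, on the aromatic carbon next to the ring nitrogen, from one aromatic ring for another to a group with no ring: in this assay compound 3 gives > 10000 nM, a limit of the assay and not a number. Placing isopropoxy where pyridin-2-yl stood gives an at least 1.2-fold higher number from compound 2 to compound 3 (0.09 log units; that floor lies within the scatter), so this change shows no gain in inhibition and no step beyond the scatter. The step between compound 1 and compound 3 cannot be read, and most of the results now sit at the same ceiling: the limit of > 10000 nM in this assay, at which 2 of the 3 values shown sit.

As far as these compounds go, it remains open how far compound 3 truly lies from compound 2, since only a floor is known. Whether an amine, a carboxylic acid or a longer alkoxy chain at this position would move the number beyond the scatter also stays unanswered.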